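From thiophen-2-yl to pyridin-3-yl on a shared core

A few compounds are considered here, and "the series" means these few. Any claim that something is new, unique, unknown or untested is made for them only; others in the source may bear on it.

Three analogues on one shared core differ only in a single aromatic group. In a functional assay on HL-60 cells (Homo sapiens) for cytotoxicity, read by CellTiter-Blue, with a stated time of 48 h (a lower number here means a stronger inhibitor, a higher number a weaker inhibitor), compound 1 `CCOC(=O)CC1C(C(=O)OCC)=C(N)Oc2ccc(-c3cccc(F)c3)cc21` with 3-fluorophenyl gives 76400 nM and compound 2 `CCOC(=O)CC1C(C(=O)OCC)=C(N)Oc2ccc(-c3cc(F)cc(F)c3)cc21` with 3,5-difluorophenyl gives 35900 nM as a measured value. Compound 3 `CCOC(=O)CC1C(C(=O)OCC)=C(N)Oc2ccc(-c3cccs3)cc21` has thiophen-2-yl and stands at > 80000 nM which is a limit and not a number.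

The change now in view is pyridin-3-yl in place of thiophen-2-yl on an aromatic carbon and the rest of the structure stays the same in compound 4 `CCOC(=O)CC1C(C(=O)OCC)=C(N)Oc2ccc(-c3cccnc3)cc21` which has not yet been measured. Going by the values given here, no measured step makes this exact exchange. Two steps leave a fluorinated phenyl for thiophen-2-yl and both are bounded from one side only: an at least 1.0-fold higher number from compound 1 to compound 3 (0.01 log units; that floor lies within the scatter) has a floor within the scatter, while an at least 2.2-fold higher number from compound 2 to compound 3 (0.34 log units; beyond the scatter) goes beyond it. The remaining step, a 2.1-fold lower number from compound 1 to compound 2 (0.33 log units; beyond the scatter) adds a fluoro, which compound 4 does not carry. Compound 1 at 76400 nM is therefore the closer guide, having a six-membered aromatic ring with a single substituent. Expected in this assay is an at least 1.1-fold lower number from compound 3 to compound 4 (0.05 log units; that floor lies within the scatter) and little or nothing beyond the scatter, with any shift toward a lower number. For compound 4 the estimated value is 70000 nM with an expected range from 30000 nM to 110000 nM and another limit is quite possible.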

Compound 4, half-maximal inhibitory concentration: 21500 nM
Compound 4: the middle estimate sits 3.3-fold (0.51 log units) above what was measured; measured number outside the range, below it.
By their numbers in this assay, from the lowest: compounds 4 and 2 (each within the scatter of the next); then compound 1. At a limit, above all of these: compound 3.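

In this assay, pyridin-3-yl in place of thiophen-2-yl gives an at least 3.7-fold lower number from compound 3 to compound 4 (0.57 log units; beyond the scatter), so exchanging one aromatic ring with a hetero atom for another at this aromatic carbon is not a neutral change. Pyridin-3-yl also separates from a fluorinated phenyl group in one case, with a 3.6-fold lower number from compound 1 to compound 4 (0.55 log units; beyond the scatter), while a 1.7-fold lower number from compound 2 to compound 4 (0.22 log units; within the scatter) leaves no order between those two compounds, so at this position a six-membered aromatic ring with a hetero atom and no fluoro matches the 3,5-difluorophenyl group of compound 2. Compound 3 remains a limit and not a number, so the first of these steps has a floor and no fixed size: the limit of > 80000 nM in this assay, at which 1 of the 4 values shown sits.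

From the compounds shown here alone, what pyridin-2-yl, pyridin-4-yl or an unsubstituted phenyl would give at this position stays open, as does the effect of an amine or a carboxylic acid on the pyridin-3-yl ring. Going by these compounds, whether the same order would hold in any other cell line also stays open, as all four compounds are compared only in this assay.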